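Compound 4 Measured Against Three Analogues at the Limit

The compounds below may be only part of what the source reports. "The series", "measured", "known", "first", "only" and "open" are said of these compounds alone.

Compound 1 `O=C(/C=C\c1ccccc1[N+](=O)[O-])N1N=C(c2ccncc2)OC1c1c[nH]c2ccccc12` is one of three close analogues tested in an ADME assay on PANC-1 cells (Homo sapiens) for cytotoxicity, read by MTT assay, with a stated time of 48 h; on this read-out lower numbers stand for stronger inhibition of growth and higher numbers for weaker inhibition of growth. Compound 1 reaches only a limit in this assay, > 30 ug/mL, which is not a number. Compound 2 `O=C(/C=C\c1cccc(F)c1)N1N=C(c2ccncc2)OC1c1c[nH]c2ccccc12` likewise stops at a limit, > 30 ug/mL. Compound 3 `O=C(/C=C\c1cccc(Cl)c1Cl)N1N=C(c2ccncc2)OC1c1c[nH]c2ccccc12` also gives only a limit, > 30 ug/mL. All three therefore sit at the limit of > 30 ug/mL in this assay, at which 3 of the 3 values shown sit, and the steps a step that the two limits leave unreadable from compound 1 to compound 2, a step that the two limits leave unreadable from compound 1 to compound 3 and a step that the two limits leave unreadable from compound 2 to compound 3 cannot be read in size or direction. Compound 4 `O=C(/C=C\c1ccc(Br)cc1)N1N=C(c2ccncc2)OC1c1c[nH]c2ccccc12` differs from compound 1 by 4-bromophenyl in place of 2-nitrophenyl on a double-bonded chain carbon bound to a double-bonded chain carbon. With every measured step unreadable, no shift beyond the scatter can be expected from this change in this assay. Compound 4 is therefore estimated at 35 ug/mL (range 15 ug/mL to 80 ug/mL), most likely again only a limit, which the expected step that the limit leaves unreadable from compound 1 to compound 4 expresses.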

Compound 4, concentration for 50% growth inhibition: > 30 ug/mL
Compound 4: no number, only a limit; the forecaster's own chance of this, stated with the estimate: 75%; the middle value does not contradict the limit.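

In this assay, among these compounds, compound 4 gives only a limit, > 30 ug/mL, and no step between compound 4 and compound 1, compound 2 or compound 3 can be read. The compounds shown leave open what actual growth-inhibition number any of them has: the limit of > 30 ug/mL in this assay, at which 4 of the 4 values shown sit.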